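This account rests on a few compounds, and the source may have more. Where it says the series, first, only, none or still open, it means among the compounds named here.

Working notes on the amide series.

The series shares one core, carried in compound 1 `CN1CCN(c2ccc(Nc3nc(-c4cccc(NC(=O)c5ccc(F)c(Cl)c5)c4)sc3C(N)=O)cc2)CC1` and compound 2 `CN1CCN(c2ccc(Nc3nc(-c4cccc(NC(=O)c5ccc(C(F)(F)F)cn5)c4)sc3C(N)=O)cc2)CC1`, and differs only in the group on the carbonyl carbon of the anilide. In a functional assay on Ramos cells (Homo sapiens) for antiproliferative activity, read by CCK-8 assay, with a stated time of 72 h, tested at 40 uM (a higher number here means more inhibition at the concentration tested (going by the name of the read-out), a lower number less inhibition), compound 1 gives 97.5%. In this assay compound 2 gives 96.6%, which is the lower of the two numbers recorded, though the step of a number 0.9 percentage points lower from compound 1 to compound 2 (within the scatter) keeps both within the scatter of each other.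

Compound 3 `CN1CCN(c2ccc(Nc3nc(-c4cccc(NC(=O)c5ccco5)c4)sc3C(N)=O)cc2)CC1` is not yet measured. Its change from compound 2 is furan-2-yl in place of 5-(trifluoromethyl)pyridin-2-yl on a carbonyl carbon. Among the measured compounds shown here, the only step that bears on it is a number 0.9 percentage points lower from compound 1 to compound 2 (within the scatter), a change at the same carbonyl carbon that left the read-out essentially unmoved. On that basis a step of similar size is expected for compound 3, with a modest downward allowance for the change to a smaller ring, amounting to a number 5.6 percentage points lower from compound 2 to compound 3 (within the scatter) in this assay. Compound 3 is therefore estimated to give 91%, in the range 72% to 99%.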

Compound 3, a percentage reported as inhibition, at one concentration (the size of the read-out at that concentration, not a potency): 96.7%
The estimate for compound 3 lay 5.7 percentage points below the measured number; the measured number falls inside the stated range.
By their numbers in this assay, from the lowest: compounds 2, 3 and 1 (each within the scatter of the next).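

In this assay, replacing the 5-(trifluoromethyl)pyridin-2-yl group with furan-2-yl gives a number 0.1 percentage points higher from compound 2 to compound 3 (within the scatter), and replacing the 3-chloro-4-fluorophenyl group with it gives a number 0.8 percentage points lower from compound 1 to compound 3 (within the scatter). A five-membered aromatic ring with fewer heavy atoms than the 5-(trifluoromethyl)pyridin-2-yl group therefore reads the same as both six-membered aromatic rings on this carbonyl carbon, so the earlier insensitivity now extends across a wider change in ring size and substitution. No supporting data bear on why the read-out stays level.

Still open, from the compounds shown here alone, is whether an aromatic ring is needed here at all, for instance whether a cyclohexyl ring, a morpholine or a longer alkyl chain on the carbonyl carbon would hold the number. A single high concentration also gives no potency, so any differences among these three compounds at lower concentrations remain unknown.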